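This account rests on a few compounds, and the source may have more. Where it says the series, first, only, none or still open, it means among the compounds named here.

The measured compounds:
Compound 1, `O=S(=O)(NCCCNCc1ccccc1Cl)c1cc(C(F)(F)F)cc(C(F)(F)F)c1`, gives 8800 nM in a functional assay on MCF7 cells (Homo sapiens) for inhibition, read by MTT assay, with a stated time of 72 h; a higher number here means a weaker inhibitor of growth, a lower number a stronger inhibitor of growth.
Compound 2, `CC(C)(C)c1ccc(CNCCCNS(=O)(=O)c2cc(C(F)(F)F)cc(C(F)(F)F)c2)cc1`, gives 2100 nM in this assay.
Compound 3, `O=S(=O)(NCCCCNCc1ccc(Br)cc1)c1cc(C(F)(F)F)cc(C(F)(F)F)c1`, gives 1500 nM in this assay.

Among these three numbers compound 3 has the lowest; compound 2 is nearest to it, and that gap is within the scatter, while compound 1 is furthest, beyond the scatter. Compound 4, `O=S(=O)(NCCCNCc1ccc(Cl)c(Cl)c1)c1cc(C(F)(F)F)cc(C(F)(F)F)c1`, has not yet been measured. It differs from compound 3 in one place: (3,4-dichlorobenzyl)amino in place of ((4-bromobenzyl)amino)methyl on a saturated chain carbon, three bonds along the chain from a sulfonamide nitrogen. Going by the values given here, two measured steps bear on this. The step of a 4.2-fold lower number from compound 1 to compound 2 (0.62 log units; beyond the scatter) shows that exchanging the benzyl group alone can move the number well beyond the scatter. The step of a 5.9-fold lower number from compound 1 to compound 3 (0.77 log units; beyond the scatter) shows that a longer chain together with a 4-bromobenzyl gives the lowest number seen. Compound 4 returns to the shorter chain of compounds 1 and 2, with a benzyl group that matches neither of those exactly. Among the compounds with values here, no step joins compound 2 to compound 3 directly; their values lie within the scatter of each other. The expected step of a 1.7-fold higher number from compound 3 to compound 4 (0.22 log units; within the scatter) is therefore a small rise, near the edge of the scatter. Compound 4 is expected to give about 2500 nM in this assay, within a range from 1000 nM to 6000 nM.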

Compound 4, concentration for 50% growth inhibition: 2400 nM
Compound 4: middle estimate off by 1.0-fold (0.02 log units), on the high side, and the stated range covers the measured number.
By their numbers in this assay, from the lowest: compounds 3, 2 and 4 (each within the scatter of the next); then compound 1.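

In this assay the step of a 3.7-fold lower number from compound 1 to compound 4 (0.56 log units; beyond the scatter) shows that 3,4-dichlorophenyl, like 4-(tert-butyl)phenyl, gives a number clearly separate from that of 2-chlorophenyl on a saturated chain carbon bound to an amine nitrogen. The step of a 1.1-fold higher number from compound 2 to compound 4 (0.06 log units; within the scatter) adds that these two quite different groups cannot be told apart at this place, so among the three compounds sharing this chain only compound 1 stands apart. The step of a 1.6-fold higher number from compound 3 to compound 4 (0.20 log units; within the scatter) also stays within the scatter, so compound 3 is not separated from compound 4, and the drop seen from compound 1 to compound 3 need not depend on the longer chain, although this step changes chain and ring substituents together and cannot divide the effect between them.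

The compounds shown leave open what a plain benzyl group, a methoxy-bearing benzyl group or a 4-bromobenzyl group on the chain of compound 4 would give, and whether a 3,4-dichlorobenzyl group on the longer chain of compound 3 would lower the number further. No measurement offered here explains why these groups give the numbers they do.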